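The compounds below may be only part of what the source reports. "The series", "measured", "known", "first", "only" and "open" are said of these compounds alone.

In a physicochemical assay for pharmacokinetics, read by HPLC, at pH 7.5, tested at 250 uM (on this read-out lower numbers stand for a shorter-lived compound and higher numbers for a longer-lived compound), compound 1 (`CC1CC(CN(C)C)C(=O)c2ccccc21`) reads 4.82 h while compound 2 (`CN(C)CC1Cc2ccccc2C1=O`) reads 0.167 h and compound 3 (`Cc1ccc2c(c1)C(=O)C(CN(C)C)C2`) reads 0.233 h on the same scale. Compound 3 thus lies within the scatter of compound 2 and well apart from compound 1. Compound 4 (`COc1ccc2c(c1)C(=O)C(CN(C)C)C2`) differs from compound 3 by methoxy in place of methyl on an aromatic carbon. Among the compounds with values here, the one measured step bearing on this is a 1.4-fold higher number from compound 2 to compound 3 (0.14 log units; within the scatter) for methyl in place of hydrogen on an aromatic carbon, within the scatter. Within the data shown here, no methoxy compound has been measured, so the expectation rests on that step alone, and no step beyond the scatter is expected in this assay from this change. The estimated step is a 1.1-fold higher number from compound 3 to compound 4 (0.03 log units; within the scatter) at this stage. Compound 4 is expected at 0.25 h with 0.13 h to 0.48 h as its estimated range.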

Compound 4, half-life: 0.2 h
Compound 4: middle estimate off by 1.3-fold (0.10 log units), on the high side, within the range that was stated.
By their numbers in this assay, from the lowest: compounds 2, 4 and 3 (each within the scatter of the next); then compound 1.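

In this assay, methoxy on this aromatic carbon, para to a fused ring or meta to a fused ring, gives a 1.2-fold lower number from compound 3 to compound 4 (0.07 log units; within the scatter) and also a 1.2-fold higher number from compound 2 to compound 4 (0.08 log units; within the scatter) in the same notes. Hydrogen, methyl and methoxy at this position therefore cannot be told apart, and the oxygen-linked group adds no separation to what the methyl step showed. No measurement here bears on the reason for this. Open, as far as these compounds go, is whether an amine, a carboxylic acid or a longer chain at this carbon would step beyond the scatter. Also open, from the compounds shown here alone, is whether methoxy would behave the same way on the core of compound 1.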